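Ethoxy for Fluoroethyl on a Cyclobutyl Side Chain

The compounds below may be only part of what the source reports. "The series", "measured", "known", "first", "only" and "open" are said of these compounds alone.

Three compounds sharing one core were tested in an assay on isolated protein for agonist activity at prostaglandin E2 receptor EP2 subtype (Homo sapiens); a higher number here means that more compound is needed for the effect, a lower number that less compound is needed. Compound 1 `CCCCC1([C@H](O)/C=C/[C@H]2COC(=O)N2CCSc2nc(C(=O)O)cs2)CCC1` gives 2.9 nM, and compound 2 `CCCCC(C)(C)[C@H](O)/C=C/[C@H]1CCC(=O)N1CCSc1nc(C(=O)O)cs1` gives 0.91 nM. Compound 3 `O=C(O)c1csc(SCCN2C(=O)OC[C@@H]2/C=C/[C@@H](O)C2(CCCCF)CCC2)n1` gives 2.9 nM, level with compound 1 and together with it the highest of the three numbers, while compound 2 sits lower. Compound 4 `CCOCCC1([C@H](O)/C=C/[C@H]2COC(=O)N2CCSc2nc(C(=O)O)cs2)CCC1` differs from compound 3 by ethoxy in place of 2-fluoroethyl on a saturated chain carbon, two bonds along the chain from a saturated ring carbon. Among the measured compounds shown here, the one measured step that bears on this change is no change at the digits printed from compound 1 to compound 3 (within the scatter), and it left the number unchanged within the scatter. For the measured compounds named here, with only that flat step to go on, a step of about zero is expected, a 1.1-fold higher number from compound 3 to compound 4 (0.04 log units; within the scatter). Compound 4 is therefore estimated at 3.2 nM, with a range from 1 nM to 10 nM.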

Compound 4, half-maximal effective concentration: 29 nM
Compound 4: the middle estimate sits 9.1-fold (0.96 log units) below what was measured; the measured number lies above the stated range.
By their numbers in this assay, from the lowest: compound 2; then compounds 1 and 3 (each within the scatter of the next); then compound 4.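

This side chain is less forgiving than the flat fluoro step suggested. In this assay there is a 10-fold higher number from compound 3 to compound 4 (1.00 log units; beyond the scatter) when ethoxy replaces 2-fluoroethyl and a 10-fold higher number from compound 1 to compound 4 (1.00 log units; beyond the scatter) when ethoxy replaces ethyl. So the chain that took fluoro in place of hydrogen without a shift does not take ethoxy, the entering group that carries a hydrogen-bond acceptor, and the loss appears from either starting compound.

Going by these compounds, whether methoxy, a longer propoxy chain or an amine at this place would behave like ethoxy stays open. Nothing available here explains the rise.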